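Swapping the Aryl on the Sulfonamide of Compound 1

The source may report more compounds than this note shows. Statements on the series, on what has been measured and on what is new or still open speak of the compounds shown alone.

Among the measured compounds shown here, compound 1 `COc1cc(N)c(Cl)cc1C(=O)CCC1CCN(CCNS(=O)(=O)c2ccc(NC(C)=O)cc2)CC1` gives 67% in an assay on HEK293 cells for displacement of a labelled ligand from 5-hydroxytryptamine receptor 6 (Homo sapiens), with a stated time of 60 min, tested at 1 uM, in the presence of a further agent that is not named here (on this read-out lower numbers stand for a weaker effect and higher numbers for a stronger effect at the one concentration tested), the higher of the two numbers known so far. Compound 2 `COc1cc(N)c(Cl)cc1C(=O)CCC1CCN(CCNS(=O)(=O)c2ccc3c(c2)NC(=O)CO3)CC1` gives 40% in this assay, and the step of a number 27 percentage points lower from compound 1 to compound 2 (beyond the scatter) came from exchanging the group on the same sulfonyl sulfur. Compound 3 `COc1ccc(S(=O)(=O)NCCN2CCC(CCC(=O)c3cc(Cl)c(N)cc3OC)CC2)cc1Br` carries a different change at that spot: 3-bromo-4-methoxyphenyl in place of 4-acetamidophenyl on a sulfonyl sulfur. For the measured compounds named here, the step from compound 1 to compound 2 is the only one bearing on this change, and it was modest. A modest fall is therefore expected for compound 3, a number 17 percentage points lower from compound 1 to compound 3 (beyond the scatter). Compound 3 is estimated at 50%, within a range from 30% to 70%.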

Compound 3, a percentage reported as inhibition, at one concentration (the size of the read-out at that concentration, not a potency): 72%
Beside the measured number, compound 3's estimate is 22 percentage points below it, and the stated range ends below it.
By their numbers in this assay, from the lowest: compound 2; then compounds 1 and 3 (each within the scatter of the next).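

In this assay the exchange gives a number 5 percentage points higher from compound 1 to compound 3 (within the scatter) so the sulfonyl sulfur can carry 3-bromo-4-methoxyphenyl, with no hydrogen-bond donor, in place of 4-acetamidophenyl without a change beyond the scatter. With a number 32 percentage points higher from compound 2 to compound 3 (beyond the scatter) as well, the fall seen earlier clearly does not follow from every exchange at this position. No evidence is available to explain these differences.

Whether the bromine, the methoxy group or the two together account for this read-out remains open. On these data alone, a plain phenyl or a 4-aminophenyl group at this position also remains untested here.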